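The source may report more compounds than this note shows. Statements on the series, on what has been measured and on what is new or still open speak of the compounds shown alone.

In a functional assay (corpus cavernosum, Oryctolagus cuniculus) (on this read-out higher numbers stand for an effect only at larger amounts of compound and lower numbers for an effect already at smaller amounts), compound 1 `COc1ccc(CNc2nc(N3CCC[C@H]3CO)ncc2C(=O)c2cc(OC)c(OC)c(OC)c2)cc1Cl` gives > 100 nM, which is a limit of the assay and not a number. Within the data shown here, compound 2 `COc1ccc(Cn2c(=O)ccc3cnc(N4CCC[C@H]4CO)nc32)cc1Cl` gives 2.2 nM, the only actual number so far. Compound 3 `COc1ccc(Cn2c(=O)cc(C)c3cnc(N4CCC[C@H]4CO)nc32)cc1Cl` differs from compound 2 in one place: methyl in place of hydrogen on an aromatic carbon. Among the measured compounds shown here, no measured pair shows what such a change does. In this assay a modest shift towards larger amounts is expected, and the estimated 1.8-fold higher number from compound 2 to compound 3 (0.26 log units; within the scatter) lies little beyond the scatter. For compound 3 the expected value is 4 nM, with an estimated range of 0.8 nM to 20 nM.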

Compound 3, half-maximal effective concentration: 0.85 nM
The estimate for compound 3 lay 4.7-fold (0.67 log units) above the measured number, within the range that was stated.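

In this assay, among these compounds, methyl in place of hydrogen on an aromatic carbon, opposite the ring nitrogen, gives a 2.6-fold lower number from compound 2 to compound 3 (0.41 log units; beyond the scatter) on the shared core, the first measured step. This position therefore accepts a single added carbon, and the number moves towards smaller amounts of compound rather than larger ones. Nothing measured here gives a reason for this step.

From the compounds shown here alone, whether an ethyl group, a longer chain, a methoxy group or an amine at this position would move the number the same way remains open. Among the compounds shown here, only this one ring position has been read, so what methyl does elsewhere on the ring also remains open.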